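The source may report more compounds than this note shows. Statements on the series, on what has been measured and on what is new or still open speak of the compounds shown alone.

Three compounds have been measured in a functional assay on SK-MEL-2 cells (Homo sapiens) for cytotoxicity, read by sulforhodamine B assay, with a stated time of 48 h; a higher number here means a weaker inhibitor of growth, a lower number a stronger inhibitor of growth:

Compound 1 `Nc1nc(Cl)c2ncn(Cc3ccccc3CCl)c2n1`: 81300 nM
Compound 2 `Nc1nc(Cl)c2ncn(Cc3ccc(CCl)cc3)c2n1`: 28800 nM
Compound 3 `ClCc1ccccc1Cn1cnc2nc(Cl)nc(Cl)c21`: 5750 nM

Compound 3 gives the lowest number of the three, and its gap to compound 2 and to compound 1 lies beyond the usual scatter, so it stands as the strongest inhibitor of growth here. Compound 4 `ClCc1ccccc1Cn1cnc2ncnc(Cl)c21` has not yet been measured in this assay. It differs from compound 3 in one place: hydrogen in place of chloro on an aromatic carbon. Going by the values given here, no measured pair shows this kind of change, so there is no step to lean on. The expectation is a modest weakening, a step of a 2.1-fold higher number from compound 3 to compound 4 (0.32 log units; beyond the scatter), with wide uncertainty. Compound 4 is therefore estimated at 12000 nM, within a range from 3000 nM to 50000 nM.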

Compound 4, concentration for total growth inhibition: 19500 nM
The estimate for compound 4 lay 1.6-fold (0.21 log units) below the measured number, within the range that was stated.
By their numbers in this assay, from the lowest: compound 3; then compounds 4 and 2 (each within the scatter of the next); then compound 1.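

In this assay, hydrogen in place of chloro on the aromatic carbon between two ring nitrogen atoms gives a 3.4-fold higher number from compound 3 to compound 4 (0.53 log units; beyond the scatter) as a modest loss of growth inhibition. The chloro at this position therefore adds to the effect, yet compound 4 still stops growth without it. Nothing measured here explains why the number rises.

Still open, from the compounds shown here alone, is how other groups at this carbon, such as a fluoro or a methoxy group, would compare with chloro. The compounds shown also leave open what hydrogen in place of the remaining chloro would do.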